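A Phenyl Group Added to Compound 1

A few compounds are considered here, and "the series" means these few. Any claim that something is new, unique, unknown or untested is made for them only; others in the source may bear on it.

Compound 1 `c1ccc(-c2ccc(Cc3cccnc3)cn2)cc1` was tested in an in vitro assay on V79MZh cells for inhibition of cytochrome P450 11B1, mitochondrial (Homo sapiens) (a lower number here means a stronger inhibitor, a higher number a weaker inhibitor), where compound 1 gives 32 nM. For the measured compounds named here, of the two compounds measured so far, compound 1 has the highest number; its only neighbour, compound 2 `Cc1ccncc1Cc1ccc(-c2ccccc2)nc1`, gives 8 nM in this assay. The change from compound 1 to compound 2 is a methyl in place of hydrogen on an aromatic carbon, and it brings a 4.0-fold lower number from compound 1 to compound 2 (0.60 log units; beyond the scatter), a modest gain that lies beyond the scatter.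

Compound 3 `c1ccc(-c2cncc(Cc3ccc(-c4ccccc4)nc3)c2)cc1` is not yet measured. It differs from compound 1 by phenyl in place of hydrogen on an aromatic carbon, placed on an aromatic carbon of a six-membered aromatic ring with one nitrogen, two atoms from the ring nitrogen and meta to a large group. Going by the values given here, no measured step matches this change: the only step known puts a much smaller group at a different place on the shared core, so it offers only weak guidance. A phenyl group is a large addition, and no measurement here shows what such a group does. Compound 3 is therefore expected to give about 40 nM in this assay, with a range from 8 nM to 200 nM, which amounts to an expected step of a 1.3-fold higher number from compound 1 to compound 3 (0.10 log units; within the scatter).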

Compound 3, half-maximal inhibitory concentration: 1.3 nM
Compound 3: middle estimate off by 31-fold (1.49 log units), on the high side; the measured number lies below the stated range.
By their numbers in this assay, from the lowest: compound 3; then compound 2; then compound 1.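

Adding a phenyl group to the shared core, two atoms from the ring nitrogen and meta to a large group, brings a 25-fold lower number from compound 1 to compound 3 (1.39 log units; beyond the scatter) in this assay, a large step. For the compounds shown here, the only earlier step, a 4.0-fold lower number from compound 1 to compound 2 (0.60 log units; beyond the scatter), came from a methyl at a different place, so it said nothing about this position or about a group of 6 heavy atoms. The new result shows that this position accepts a whole extra six-membered aromatic ring of carbon only, and that the compound carrying it is a much stronger inhibitor than compound 1, although nothing measured here explains the gain.

Going by these compounds alone, with only one group at this position, it remains open whether the gain needs a ring of this size, or whether an amine, a carboxylic acid or a short alkyl chain at the same place would also lower the number. Going by these compounds, it is also open whether the phenyl of compound 3 and the methyl of compound 2 would add up if both stood on the shared core.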